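The source may hold more compounds than are shown below. What is called first, only, known or untested is meant among the compounds shown, and "the series" means these compounds.

Compound 1 `COc1ccc(F)cc1CNCCCNc1ccnc2cc(-c3ccc(F)cc3)ccc12`: 770 nM
Compound 2 `COc1ccc(F)cc1CNCCCNc1ccnc2cc(Oc3ccc(F)cc3)ccc12`: 6600 nM

In an ADME assay on HepG2 cells (Homo sapiens) for cytotoxicity, read by luminescence, CellTiter-Glo and ATP content, with a stated time of 72 h (a lower number here means that less compound is needed, a higher number that more compound is needed for the effect), compound 2 stands at the highest of the two numbers; its nearest neighbour is compound 1, and the step of an 8.6-fold higher number from compound 1 to compound 2 (0.93 log units; beyond the scatter) lies beyond the scatter. Compound 3 `COc1ccc(F)cc1CNCCCNc1ccnc2cc(Oc3ccccc3)ccc12` differs from compound 2 by hydrogen in place of fluoro on an aromatic carbon. Going by the values given here, the single measured step, an 8.6-fold higher number from compound 1 to compound 2 (0.93 log units; beyond the scatter), concerns a different change and does not bear on removal of the fluoro; no measured pair speaks to this change. A step within the scatter is therefore expected, with no direction favoured. Compound 3 is expected to give about 6000 nM in this assay, within 2500 nM to 15000 nM, a step of a 1.1-fold lower number from compound 2 to compound 3 (0.04 log units; within the scatter) from compound 2.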

Compound 3, half-maximal effective concentration: 1500 nM
Compound 3: the middle estimate sits 4.0-fold (0.60 log units) above what was measured; measured number below the stated range.
By their numbers in this assay, from the lowest: compounds 1 and 3 (each within the scatter of the next); then compound 2.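

In this assay, the fluoro on the phenoxy group is not a silent atom: removing it from its place para to a large group gives a step beyond the scatter (a 4.4-fold lower number from compound 2 to compound 3 (0.64 log units; beyond the scatter)). Without that fluoro, the phenoxy compound no longer separates from the 4-fluorophenyl compound (a 1.9-fold higher number from compound 1 to compound 3 (0.29 log units; within the scatter)). Nothing measured on these compounds explains the effect of the fluoro.

On these data alone, it remains open whether removing the fluoro from 4-fluorophenyl would give a similar step. As far as these compounds go, how chloro or methoxy would read in the same place also remains open.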